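Acetyl to Ethoxycarbonyl: What to Expect for Compound 3

The source may hold more compounds than are shown below. What is called first, only, known or untested is meant among the compounds shown, and "the series" means these compounds.

Compound 1 `Cc1ccc(S(=O)(=O)NNc2nc(C)cs2)cc1` gives < 5650 nM in a functional assay on HepG2 cells (Homo sapiens) for inhibition, read by XTT assay, with a stated time of 72 h; a lower number here means a stronger inhibitor, a higher number a weaker inhibitor; this is a limit of the assay, not a number.
Compound 2 `CC(=O)c1sc(NNS(=O)(=O)c2ccc(C)cc2)nc1C` gives 8770 nM in this assay.

Within the data shown here, compound 2 holds the only plain number in this set; the other value is a limit (the limit of < 5650 nM in this assay, at which 1 of the 2 values shown sits). Among the measured compounds shown here, the one measured step, an at least 1.5-fold higher number from compound 1 to compound 2 (0.19 log units; that floor lies within the scatter), comes from acetyl in place of hydrogen on an aromatic carbon, and its floor lies within the scatter.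

Compound 3 `CCOC(=O)c1sc(NNS(=O)(=O)c2ccc(C)cc2)nc1C` has not been measured. It differs from compound 2 as follows: ethoxy in place of methyl on a carbonyl carbon. For the measured compounds named here, no measured step alters a group already sitting on that carbonyl carbon, so the step from compound 1 to compound 2 gives no direct guide here. Without such evidence, the expected step for compound 3 is a 1.1-fold lower number from compound 2 to compound 3 (0.04 log units; within the scatter), no larger than the scatter. Compound 3 is therefore estimated at 8000 nM, with a range from 3000 nM to 25000 nM.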

Compound 3, half-maximal inhibitory concentration: < 4510 nM
Compound 3 ended at the assay's limit (the forecaster's own chance of this, stated with the estimate: 25%); middle value at least 1.7-fold (0.24 log units) from the limit.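

Among these compounds, compound 2 and compound 3 give the first look at a change made on the carbonyl carbon itself, where ethoxy takes the place of methyl, and in this assay this gives an at least 1.9-fold lower number from compound 2 to compound 3 (0.28 log units; that floor lies within the scatter). The full size of this step stays unknown because the result for compound 3 is a limit of the assay and not a number: the limit of < 4510 nM in this assay, at which 1 of the 3 values shown sits.

Going from acetyl to ethoxycarbonyl brings no rise in the number, though the step from compound 1 to compound 3 cannot be read, both results being limits. The compounds shown leave open whether a longer chain in place of ethoxy would move the number beyond the scatter. They also leave open what an amine or a hydroxyl group would do on the same carbonyl carbon.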